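Adding a trifluoromethoxy group to the inactive parent

The source may hold more compounds than are shown below. What is called first, only, known or untested is meant among the compounds shown, and "the series" means these compounds.

Measured in a functional assay on A549 cells (Homo sapiens) for antiproliferative activity, read by MTT assay (on this read-out lower numbers stand for stronger inhibition and higher numbers for weaker inhibition), the values are as follows:
- compound 1 `Cn1c(=O)c(=O)n(C2CCCC2)c2nc(N/N=C/c3ccccc3)ncc21` gives > 100000 nM as a limit of the assay
- compound 2 `Cn1c(=O)c(=O)n(C2CCCC2)c2nc(N/N=C/c3ccc(F)c(Cl)c3)ncc21` gives 9410 nM
- compound 3 `Cn1c(=O)c(=O)n(C2CCCC2)c2nc(N/N=C/c3cccc([N+](=O)[O-])c3)ncc21` gives 12300 nM

Compound 1 stands at the limit of > 100000 nM in this assay, at which 1 of the 3 values shown sits, on these numbers, and only a limit is known for it. The next analogue, compound 4 `Cn1c(=O)c(=O)n(C2CCCC2)c2nc(N/N=C/c3ccc(OC(F)(F)F)cc3)ncc21` has trifluoromethoxy in place of hydrogen on an aromatic carbon, para to a large group (trifluoromethoxy in place of hydrogen on an aromatic carbon). Going by the values given here, two measured steps bear on this change. Replacing phenyl with 3-chloro-4-fluorophenyl gave an at least 10-fold lower number from compound 1 to compound 2 (1.02 log units; beyond the scatter) and placing nitro on the aromatic ring gave an at least 8.1-fold lower number from compound 1 to compound 3 (0.91 log units; beyond the scatter) in the same direction. The two substituted analogues sit level, with a 1.3-fold higher number from compound 2 to compound 3 (0.12 log units; within the scatter) between them. Neither step tests trifluoromethoxy itself, but a step of similar size towards a lower number is expected in this assay for the new group. The expected change is an at least 6.6-fold lower number from compound 1 to compound 4 (0.82 log units; beyond the scatter) on this estimate. Compound 4 is estimated at 15000 nM in this assessment. The expected range for compound 4 runs from 5000 nM to 50000 nM on the same reasoning.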

Compound 4, half-maximal inhibitory concentration: 12900 nM
Estimate against measurement, compound 4: 1.2-fold (0.07 log units) above; measured number inside the range.
By their numbers in this assay, from the lowest: compounds 2, 3 and 4 (each within the scatter of the next). At a limit, above all of these: compound 1.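

In this assay, a single trifluoromethoxy group on an aromatic carbon, para to a large group, is enough to give an at least 7.7-fold lower number from compound 1 to compound 4 (0.88 log units; beyond the scatter), so this place on the ring also responds to substitution. Compound 1 is known only as a limit, so this step gives only a bound on the size of the change: the limit of > 100000 nM in this assay, at which 1 of the 4 values shown sits. Compounds 2, 3 and 4 each lie within the scatter of the next, so three different ring substitutions leave the parent's limit and reach similar values, and none of them stands out.

Whether this level depends on the trifluoromethoxy group itself remains open, as the compounds shown do not include a methoxy group at this place. On these data alone, how an amine or a carboxylic acid would read there is also open.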